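Changing the Aryl Group on a Long-Chain Amide

The source may hold more compounds than are shown below. What is called first, only, known or untested is meant among the compounds shown, and "the series" means these compounds.

In a functional assay on WM164 cells (Homo sapiens) for antiproliferative activity, read by sulforhodamine B assay, with a stated time of 48 h (on this read-out lower numbers stand for stronger inhibition and higher numbers for weaker inhibition), compound 1 `CCCCCCCCCCCCNC(=O)[C@@H]1CSC(c2ccc(OC)c(OC)c2)N1` gives 1600 nM, compound 2 `CCCCCCCCCCCCCCNC(=O)[C@@H]1CSC(c2ccc(OC)c(OC)c2)N1` gives 800 nM and compound 3 `CCCCCCCCCCCCCCCCNC(=O)[C@@H]1CSC(c2ccc(OC)c(OC)c2)N1` gives 500 nM. Compound 3 sits within the scatter of compound 2, as shown by a 1.6-fold lower number from compound 2 to compound 3 (0.20 log units; within the scatter), but clearly apart from compound 1, as shown by a 3.2-fold lower number from compound 1 to compound 3 (0.51 log units; beyond the scatter). Compound 4 `CCCCCCCCCCCCCCCCNC(=O)[C@@H]1CSC(c2ccc(N)cc2)N1` keeps the chain of compound 3 and carries 4-aminophenyl in place of 3,4-dimethoxyphenyl on a saturated ring carbon. Going by the values given here, all the measured steps alter the chain, so none of them tests this swap, and the largest offers only a rough scale. A small rise within the scatter is expected, and the estimated step is a 1.6-fold higher number from compound 3 to compound 4 (0.20 log units; within the scatter). Compound 4 is estimated at 800 nM, with an expected range of 250 nM to 2500 nM.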

Compound 4, half-maximal inhibitory concentration: 1400 nM
Compound 4: the middle estimate sits 1.8-fold (0.24 log units) below what was measured; the range from low to high includes it.
By their numbers in this assay, from the lowest: compounds 3, 2, 4 and 1 (each within the scatter of the next, the first and the last beyond it).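

Going by these compounds alone, with the chain held fixed, this is the first look at the aryl group on the saturated ring carbon, and in this assay replacing 3,4-dimethoxyphenyl with 4-aminophenyl gives a 2.8-fold higher number from compound 3 to compound 4 (0.45 log units; beyond the scatter), so this position responds to change. The swap removes two methoxy groups and adds an amino group in one move, leaving the step unassigned to either. Nothing available explains the step. As far as these compounds go, whether plain phenyl or 4-methoxyphenyl would sit nearer compound 3 or compound 4 stays open. So does whether the same swap gives a similar step on the shorter chain of compound 1.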